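The source may hold more compounds than are shown below. What is called first, only, known or untested is meant among the compounds shown, and "the series" means these compounds.

Working notes on the series. In an ADME assay on CHO cells (Cricetulus griseus) for cytotoxicity, read by MTT assay, with a stated time of 72 h (a lower number here means that less compound is tolerated, a higher number that more compound is tolerated), compound 1 (`CCOC(=O)c1c(-c2ccc(F)cc2)oc2ccc(OCCN3C(=O)C(=O)c4cc(F)ccc43)cc12`) gives 64000 nM, and compound 2 (`CCOC(=O)c1c(-c2ccccc2)oc2ccc(OCCN3C(=O)C(=O)c4cc(F)ccc43)cc12`) gives 64000 nM, so the two stand level at the digits shown. Going by the values given here, compound 1 therefore sits with its only measured neighbour, and nothing yet separates the pair.

The next compound is compound 3 (`CCOC(=O)c1c(-c2ccc(F)cc2)oc2ccc(OCCCN3C(=O)C(=O)c4ccccc43)cc12`), and its change from compound 1 is a group of 12 heavy atoms (9 carbon, 1 nitrogen, 2 oxygen; one five-membered non-aromatic ring with 1 hetero atom, one six-membered aromatic ring of carbon only) in place of a group of 12 heavy atoms (8 carbon, 1 nitrogen, 2 oxygen, 1 fluorine; one five-membered non-aromatic ring with 1 hetero atom, one six-membered aromatic ring of carbon only), on a saturated chain carbon, two bonds along the chain from an oxygen on an aromatic ring. The exchange lies on a saturated chain carbon, two bonds along the chain from an oxygen on an aromatic ring.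

Among the compounds with values here, the only measured step that bears on this is no change at the digits printed from compound 1 to compound 2 (within the scatter), hydrogen in place of fluoro on an aromatic carbon, and it lies within the scatter. Within the data shown here, it is an indirect guide, since no measured compound shows the effect of changing the chain. On that limited evidence, no shift beyond the scatter is expected in this assay, and no direction is favoured.

The expected step is a 1.1-fold lower number from compound 1 to compound 3 (0.03 log units; within the scatter).

For compound 3 the estimated value is 60000 nM, with an expected range of 30000 nM to 120000 nM.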

Compound 3, half-maximal cytotoxic concentration: 256000 nM
For compound 3 the middle estimate is 4.3-fold (0.63 log units) below the measured one; measured number outside the range, above it.
By their numbers in this assay, from the lowest: compounds 1 and 2 (each within the scatter of the next); then compound 3.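

In this assay, going by these compounds alone, the exchange on a saturated chain carbon, two bonds along the chain from an oxygen on an aromatic ring, gives a 4.0-fold higher number from compound 1 to compound 3 (0.60 log units; beyond the scatter), the first step to lie beyond the scatter. The earlier step, with hydrogen in place of fluoro on an aromatic carbon, gave no change at the digits printed from compound 1 to compound 2 (within the scatter), so the number responds at this chain position in a way that the aromatic-carbon exchange did not show, although the entering and leaving groups match in heavy atoms, ring types, hydrogen-bond donors and acceptors, and net charge, and differ only in a carbon in place of a fluorine. Within the data shown here, nothing measured so far gives a reason for this step.

The compounds shown do not separate the carbon gained from the fluorine lost, so it remains open which of the two carries the step. On these data alone, it is also open whether a longer chain, or an amine or a carboxylic acid at this place, would move the number further in the same direction or reverse it.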